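The compounds below may be only part of what the source reports. "The series", "measured", "known", "first", "only" and "open" are said of these compounds alone.

Compounds measured in a functional assay on NPC-TW01 cells (Homo sapiens) for inhibition, read by MTT assay, with a stated time of 72 h; on this read-out lower numbers stand for stronger inhibition of growth and higher numbers for weaker inhibition of growth:
compound 1 `CN(C)/C=N/c1c(C=O)c(-c2ccccc2)nn1-c1ccccc1` gives 9300 nM
compound 2 `COc1ccc(-n2nc(-c3ccccc3)c(C=O)c2/N=C/N(C)C)cc1` gives 20200 nM
compound 3 `Cc1ccc(-c2nn(-c3ccccc3)c(/N=C/N(C)C)c2C=O)cc1` gives 9700 nM

Compound 3 stands second highest of the three numbers in this assay. Its nearest neighbour is compound 1, and the gap between them is within the scatter; only compound 2 lies beyond the scatter from compound 3, as a higher number.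

Compound 4 `CN(C)/C=N/c1c(C=O)c(-c2ccc(Cl)cc2)nn1-c1ccccc1` is not yet measured. It differs from compound 3 in one place: chloro in place of methyl on an aromatic carbon. For the measured compounds named here, no measured pair shows chloro entering at this spot, so the expectation rests on the two steps that touch the same kind of position on the shared core. A methyl at that place changed little, a 1.0-fold higher number from compound 1 to compound 3 (0.02 log units; within the scatter), while a methoxy on the other phenyl ring gave a higher number, a 2.2-fold higher number from compound 1 to compound 2 (0.34 log units; beyond the scatter). Both steps are small, and neither reverses direction strongly, so only a small step, if any, is expected in this assay from compound 3 to compound 4, a 1.1-fold lower number from compound 3 to compound 4 (0.03 log units; within the scatter). On that basis compound 4 is estimated to give 9000 nM in this assay, with a range from 4000 nM to 20000 nM that reflects the absence of any measured chloro analogue.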

Compound 4, concentration for 50% growth inhibition: 8100 nM
For compound 4 the middle estimate is 1.1-fold (0.05 log units) above the measured one; low and high end bracket the measured number.
By their numbers in this assay, from the lowest: compounds 4, 1 and 3 (each within the scatter of the next); then compound 2.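

In this assay, compound 4 brings the first chloro to this place, on the aromatic carbon para to a large group, and the change from 4-methylphenyl to 4-chlorophenyl comes to a 1.2-fold lower number from compound 3 to compound 4 (0.08 log units; within the scatter). Set against the plain phenyl of compound 1, the chloro gives a 1.1-fold lower number from compound 1 to compound 4 (0.06 log units; within the scatter), so hydrogen, methyl and chloro at this place cannot be told apart in this assay across compound 1, compound 3 and compound 4, while the only step beyond the scatter among the compounds shown remains the methoxy on the other phenyl ring, a 2.2-fold higher number from compound 1 to compound 2 (0.34 log units; beyond the scatter). Nothing measured here offers an explanation for why these three compounds read alike.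

The compounds shown leave open whether this place would stay as undemanding with a group of a different kind, such as an amine, a carboxylic acid or a longer chain, since only hydrogen, methyl and chloro have been seen there. They also leave open what chloro would do on the other phenyl ring, where methoxy is the only group shown, and how the remaining parts of the shared core bear on growth inhibition.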